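Aryl swap on the sulfonyl sulfur: compound 3 to compound 4

This account rests on a few compounds, and the source may have more. Where it says the series, first, only, none or still open, it means among the compounds named here.

Compound 3 `COc1ccc(S(=O)(=O)c2cnc3c(F)cccc3c2N2CCC(C)CC2)cc1` gives 67% in an assay on isolated protein for displacement of a labelled ligand from metabotropic glutamate receptor 5 (Homo sapiens), with a stated time of 60 min, tested at 1 uM (on this read-out higher numbers stand for more inhibition at the one concentration tested (going by the name of the read-out) and lower numbers for less inhibition), the lowest of the three measured values. Compound 1 `CC1CCN(c2c(S(=O)(=O)c3cc(Cl)cc(Cl)c3)cnc3c(F)cccc23)CC1` gives 82% and compound 2 `Cc1ccc(S(=O)(=O)c2cnc3c(F)cccc3c2N2CCC(C)CC2)cc1` gives 93%. Both a number 15 percentage points lower from compound 1 to compound 3 (beyond the scatter) and a number 26 percentage points lower from compound 2 to compound 3 (beyond the scatter) place the 4-methoxyphenyl on the sulfonyl sulfur below its two measured neighbours. Compound 4 `CC1CCN(c2c(S(=O)(=O)c3ccc(Cl)c(Cl)c3)cnc3c(F)cccc23)CC1` alters this group: 3,4-dichlorophenyl in place of 4-methoxyphenyl on a sulfonyl sulfur. The closest measured comparison is the reverse direction of a number 15 percentage points lower from compound 1 to compound 3 (beyond the scatter), a dichlorophenyl with a different substitution pattern; the 4-methylphenyl case, a number 11 percentage points higher from compound 1 to compound 2 (beyond the scatter), lies somewhat higher still. The expected step is therefore a rise, a number 13 percentage points higher from compound 3 to compound 4 (beyond the scatter), of about the size seen with compound 1. Compound 4 is expected to give 80%, with a range from 65% to 92%.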

Compound 4, a percentage reported as inhibition, at one concentration (the size of the read-out at that concentration, not a potency): 95%
Beside the measured number, compound 4's estimate is 15 percentage points below it, and the stated range ends below it.
By their numbers in this assay, from the lowest: compound 3; then compound 1; then compounds 2 and 4 (each within the scatter of the next).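

Two chlorines on the aryl group do not fix the read-out on their own: 3,4-dichlorophenyl on a sulfonyl sulfur differs from 3,5-dichlorophenyl (a number 13 percentage points higher from compound 1 to compound 4 (beyond the scatter)). 3,4-Dichlorophenyl also recovers the loss seen with 4-methoxyphenyl (a number 28 percentage points higher from compound 3 to compound 4 (beyond the scatter)) and matches 4-methylphenyl (a number 2 percentage points higher from compound 2 to compound 4 (within the scatter)), so two quite different aryl groups give comparable numbers here. No evidence is available to explain these differences.

From the compounds shown here alone, whether an aryl group carrying an amine or a carboxylic acid would keep this level remains open. So does the behaviour of a longer chain on the sulfonyl sulfur in place of the aryl group.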